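Moving the fluorine on the benzyl group of compound 3

A few compounds are considered here, and "the series" means these few. Any claim that something is new, unique, unknown or untested is made for them only; others in the source may bear on it.

Compound 3 `O=C(C1CC1)N1CCN(Cc2nc3ccccc3n2Cc2cccc(F)c2)CC1` stands second highest of the three numbers in an assay on isolated protein for inhibition of aldehyde dehydrogenase 1A1 (Homo sapiens), read by spectrophotometry, tested at 10 uM; on this read-out higher numbers stand for more inhibition at the one concentration tested (going by the name of the read-out) and lower numbers for less inhibition. In this assay compound 3 gives 27.2%. Compound 1 `CC(C)Cn1c(CN2CCN(C(=O)C3CC3)CC2)nc2ccccc21` gives 13.1% in this assay, and the step of a number 14.1 percentage points higher from compound 1 to compound 3 (beyond the scatter). Compound 2 `CC(C)=CCn1c(CN2CCN(C(=O)C3CC3)CC2)nc2ccccc21` gives 74.3% in this assay; the step of a number 47.1 percentage points lower from compound 2 to compound 3 (beyond the scatter), and the step of a number 61.2 percentage points higher from compound 1 to compound 2 (beyond the scatter).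

Compound 4 `O=C(C1CC1)N1CCN(Cc2nc3ccccc3n2Cc2ccccc2F)CC1` differs from compound 3 by 2-fluorophenyl in place of 3-fluorophenyl on a saturated chain carbon bound to an aromatic nitrogen. None of the three measured steps moves a fluorine within an aromatic ring; each exchanges one whole group on the saturated chain carbon bound to an aromatic nitrogen for another. They therefore offer no direct guide to this change, and they show only that this position can shift the number strongly. Among the compounds with values here, with no step bearing on it, the expectation for compound 4 is no step beyond the scatter, a number 0.2 percentage points lower from compound 3 to compound 4 (within the scatter), while a broad range is allowed. Compound 4 is estimated at 27%, expected between 8% and 55%.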

Compound 4, a percentage reported as inhibition, at one concentration (the size of the read-out at that concentration, not a potency): 40.7%
For compound 4 the middle estimate is 13.7 percentage points below the measured one, and the stated range covers the measured number.
By their numbers in this assay, from the lowest: compound 1; then compound 3; then compound 4; then compound 2.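

In this assay, moving the fluorine within the ring, with no change in the atoms of the group, is enough to shift the number: a number 13.5 percentage points higher from compound 3 to compound 4 (beyond the scatter). This position therefore responds to where the fluorine sits on the aromatic ring, and not only to which whole group is attached to the saturated chain carbon, although the measured data give no reason for this. The 2-fluorophenyl group still falls in the middle of the series, with a number 27.6 percentage points higher from compound 1 to compound 4 (beyond the scatter) and a number 33.6 percentage points lower from compound 2 to compound 4 (beyond the scatter).

Still open, as far as these compounds go, is how a plain phenyl group on the same chain carbon would read, and whether chlorine in place of the fluorine of 2-fluorophenyl would keep the higher number. Also open, from the compounds shown here alone, is whether a longer alkene chain would match or pass compound 2.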